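Furan in place of the carboxamide-bearing benzene ring

A few compounds are considered here, and "the series" means these few. Any claim that something is new, unique, unknown or untested is made for them only; others in the source may bear on it.

Among the compounds with values here, compound 2 `NCc1cc(C(N)=O)ccc1CN(Cc1nc2ccccc2[nH]1)C1CCCc2cccnc21` gives 15 nM in a functional assay on CEM-CCRF cells for antagonist activity at C-X-C chemokine receptor type 4 (Homo sapiens), read by calcium flux (a higher number here means a weaker inhibitor, a lower number a stronger inhibitor), the lower of the two numbers so far; compound 1 `NCc1cc(C(=O)O)ccc1CN(Cc1nc2ccccc2[nH]1)C1CCCc2cccnc21` gives 126 nM. Within the data shown here, the only measured step, an 8.4-fold lower number from compound 1 to compound 2 (0.92 log units; beyond the scatter), concerns the carbonyl substituent and not the ring itself. Compound 3 `NCc1ccoc1CN(Cc1nc2ccccc2[nH]1)C1CCCc2cccnc21` carries a group of 7 heavy atoms (5 carbon, 1 nitrogen, 1 oxygen; one five-membered aromatic ring with 1 hetero atom) in place of a group of 11 heavy atoms (8 carbon, 2 nitrogen, 1 oxygen; one six-membered aromatic ring of carbon only), on a saturated chain carbon bound to an amine nitrogen, so the carboxamide that distinguished compound 2 from compound 1 is gone along with the ring that bore it. Among the measured compounds shown here, no measured step bears directly on this change; a weakening is expected, with wide uncertainty, as a 4.0-fold higher number from compound 2 to compound 3 (0.60 log units; beyond the scatter). Compound 3 is estimated at 60 nM, within 15 nM to 300 nM.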

Compound 3, half-maximal inhibitory concentration: 12 nM
The estimate for compound 3 lay 5.0-fold (0.70 log units) above the measured number; measured number outside the range, below it.
By their numbers in this assay, from the lowest: compounds 3 and 2 (each within the scatter of the next); then compound 1.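

In this assay the step of a 1.3-fold lower number from compound 2 to compound 3 (0.10 log units; within the scatter) shows that the place on a saturated chain carbon bound to an amine nitrogen accepts the furan in place of the benzene ring, even with the carbonyl group gone. The carboxamide of compound 2 is therefore not needed for a number in this range, and the step of an 11-fold lower number from compound 1 to compound 3 (1.02 log units; beyond the scatter) keeps compound 3 clear of the carboxylic acid compound 1. Nothing available accounts for this result.

As far as these compounds go, whether a carboxamide or a carboxylic acid carried on the furan would shift the number remains open. So does whether a thiophene would read like the furan.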